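The source may hold more compounds than are shown below. What is called first, only, known or untested is meant among the compounds shown, and "the series" means these compounds.

Of the compounds shown here, three that share a common core have been measured in a functional assay on HOS-TE85 cells (Homo sapiens) for inhibition, read by CCK-8 assay, with a stated time of 72 h; a lower number here means a stronger inhibitor, a higher number a weaker inhibitor. Compound 1 `O=C(NCCCCc1ccccc1)c1cc(F)cc(C2SCC(=O)N2c2ccccn2)c1` gives 14.2 nM. Compound 2 `COc1ccccc1N1C(=O)CSC1c1cc(F)cc(C(=O)NCCCCc2ccccc2)c1` gives 40.9 nM. Compound 3 `COc1ccccc1N1C(=O)CSC1c1cccc(C(=O)NCCCCn2cccn2)c1` gives 91.7 nM, the highest of the three numbers; its gap to compound 2 lies beyond the scatter, and its gap to compound 1 is wider still. The difference between the core of compound 2 and the core of compound 3 is not broken down here. Compounds 2 and 1 differ in one place only: pyridin-2-yl in place of 2-methoxyphenyl on an amide-type nitrogen in a ring. That change produced a 2.9-fold lower number from compound 2 to compound 1 (0.46 log units; beyond the scatter).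

Compound 4 `O=C(NCCCCn1cccn1)c1cccc(C2SCC(=O)N2c2ccccn2)c1` has not yet been measured in this assay. It relates to compound 3 exactly as compound 1 relates to compound 2: pyridin-2-yl in place of 2-methoxyphenyl on an amide-type nitrogen in a ring. The place of the change is described in the same words for both pairs, so it is the same change carried onto the core of compound 3. The expectation for compound 4 rests on the single earlier step of a 2.9-fold lower number from compound 2 to compound 1 (0.46 log units; beyond the scatter), which is the only measured instance of this change among the compounds shown, and the range is kept wide for that reason. Compound 4 is expected to give 32 nM in this assay, with the likely span running from 15 nM to 70 nM. The step from compound 3 to compound 4 is thus estimated as a 2.9-fold lower number from compound 3 to compound 4 (0.46 log units; beyond the scatter), mirroring the earlier one.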

Compound 4, half-maximal inhibitory concentration: 60.3 nM
Beside the measured number, compound 4's estimate is 1.9-fold (0.28 log units) below it, and the stated range covers the measured number.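

On the core of compound 3, pyridin-2-yl in place of 2-methoxyphenyl on the amide-type nitrogen in the ring gave a 1.5-fold lower number from compound 3 to compound 4 (0.18 log units; within the scatter) in this assay, so on this core the change alone cannot be told apart from repeat measurement. Set beside the earlier step, the result does not separate the two cores, and the change can be read as consistent across them: the same change on two cores in this assay, a 2.9-fold lower number (0.46 log units; beyond the scatter) from compound 2 to compound 1 and a 1.5-fold lower number (0.18 log units; within the scatter) from compound 3 to compound 4, 1.9-fold (0.28 log units) apart, within the scatter of two such steps. Among the compounds shown here, this does not show that the change has one fixed size wherever it is placed, nor that it lowers the number on every core, as only one of the two steps lies beyond the scatter and two instances are too few to define a trend.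

The compounds shown do not break down the difference between the two cores, so it remains open whether any part of that difference alters the size of the step. Also open, going by these compounds, is how a methyl or cyclohexyl group on the amide-type nitrogen in the ring would read on either core, and whether a longer chain or a terminal amine on the amide side would leave the step unchanged.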